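The source may hold more compounds than are shown below. What is called first, only, known or untested is meant among the compounds shown, and "the series" means these compounds.

Compound 1 `O=S(=O)(/C=C/c1ccccc1)Cc1ccc(Nc2ncnc3ccccc23)cc1`: > 100000 nM
Compound 2 `O=S(=O)(/C=C/c1ccc(Cl)cc1)Cc1ccc(Nc2ncnc3ccccc23)cc1`: 49000 nM

In a functional assay on U-251 cells (Homo sapiens) (a lower number here means a stronger inhibitor of growth, a higher number a weaker inhibitor of growth), compound 1 gives > 100000 nM, which is a limit of the assay and not a number. Within the data shown here, compound 2 gives 49000 nM, the only true number so far. Compound 3 `O=S(=O)(/C=C/c1ccc(F)cc1Cl)Cc1ccc(Nc2ncnc3ccccc23)cc1` differs from it as follows: 2-chloro-4-fluorophenyl in place of 4-chlorophenyl on a double-bonded chain carbon bound to a double-bonded chain carbon. It carries 2-chloro-4-fluorophenyl in place of 4-chlorophenyl. Among the measured compounds shown here, only one measured step bears on this, an at least 2.0-fold lower number from compound 1 to compound 2 (0.30 log units; that floor lies within the scatter), with chloro in place of hydrogen on an aromatic carbon. That step gives only a floor, so a small move towards a lower number is expected. The expected change is a 1.6-fold lower number from compound 2 to compound 3 (0.21 log units; within the scatter), which would stay within the scatter. For compound 3 the estimated value is 30000 nM, with an expected range of 10000 nM to 90000 nM.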

Compound 3, concentration for 50% growth inhibition: 100000 nM
The estimate for compound 3 lay 3.3-fold (0.52 log units) below the measured number; measured number outside the range, above it.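

In this assay, replacing 4-chlorophenyl with 2-chloro-4-fluorophenyl on a double-bonded chain carbon bound to a double-bonded chain carbon gives a 2.0-fold higher number from compound 2 to compound 3 (0.31 log units; beyond the scatter) and this modest move runs opposite in direction to the earlier chloro step. Compound 3 therefore goes against any rule that more halogen on this phenyl ring lowers the number. From the compounds shown here alone, there is also a number no higher from compound 1 to compound 3 (the limit leaves the size open) and its size stays open. That size cannot be read because the value of compound 1 is a limit: the limit of > 100000 nM in this assay, at which 1 of the 3 values shown sits.

This step both adds fluoro and changes where the chloro sits, and the compounds shown do not separate the two. Going by these compounds, how an amine or a methoxy group on this ring would fare also stays open.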